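Trimming the bromophenyl urea tail in a quinoline series

The compounds below may be only part of what the source reports. "The series", "measured", "known", "first", "only" and "open" are said of these compounds alone.

Of the compounds shown here, two carrying the same core have been tested in a functional assay on CCRF-CEM cells (Homo sapiens) for inhibition, read by MTT assay, with a stated time of 72 h; a lower number here means a stronger inhibitor, a higher number a weaker inhibitor. Compound 1, `COc1cc(NC(C)CCCNC(=O)NNC(=O)Nc2cc(C(F)(F)F)cc(C(F)(F)F)c2)c2ncccc2c1`, gives 13000 nM in this assay. Compound 2, `COc1cc(NC(C)CCCNC(=O)NNC(=O)Nc2ccc(Br)cc2)c2ncccc2c1`, gives 110000 nM in this assay, the higher of the two numbers and therefore the weaker inhibitor of the pair, with its gap to compound 1 lying beyond the usual scatter.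

Compound 3, `COc1cc(NC(C)CCCNC(=O)Nc2cccc(Cl)c2)c2ncccc2c1`, has not yet been measured. It differs from compound 2 in one place: 3-chlorophenyl in place of ((4-bromophenyl)carbamoyl)amino on an amide-type nitrogen. The long tail of compound 2 is thus cut back to a single aryl group sitting on the amide-type nitrogen.

Within the data shown here, no measured pair here isolates a change of this kind, so the direction can only be guessed from what the two known compounds show. With compound 2 sitting at 110000 nM, a step toward a lower number is expected, though it may not clear the scatter; the estimated step is a 2.2-fold lower number from compound 2 to compound 3 (0.34 log units; beyond the scatter). Compound 3 is therefore expected to give about 50000 nM in this assay, within a range from 12000 nM to 200000 nM.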

Compound 3, half-maximal inhibitory concentration: 22000 nM
Beside the measured number, compound 3's estimate is 2.3-fold (0.36 log units) above it; the range from low to high includes it.
By their numbers in this assay, from the lowest: compounds 1 and 3 (each within the scatter of the next); then compound 2.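

In this assay, the long tail on the amide-type nitrogen turns out not to be required for inhibition: replacing ((4-bromophenyl)carbamoyl)amino with 3-chlorophenyl gives a 5.0-fold lower number from compound 2 to compound 3 (0.70 log units; beyond the scatter). This position therefore accepts a much shorter group, with fewer heavy atoms and none of the hydrogen-bond donors or acceptors of the group that leaves, and the number improves rather than worsens. No measurement shown explains why the number falls.

This single step changes two things at once, the length of the tail and the aryl group with its halogen, so the compounds shown leave open which of the two accounts for the difference. Also open, on these data alone, is how the number would respond to other groups on the same nitrogen, such as an unsubstituted phenyl, a longer chain ending in an amine, or a phenyl ring carrying a carboxylic acid.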